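This account rests on a few compounds, and the source may have more. Where it says the series, first, only, none or still open, it means among the compounds named here.

Measured compounds:
Compound 1, `CCCn1c(=O)[nH]c2nc(-c3ccc(S(=O)(=O)N4CCN(Cc5ccc(Br)cc5)CC4)cc3)[nH]c2c1=O`: 31%
Compound 2, `CCCn1c(=O)[nH]c2nc(-c3ccc(S(=O)(=O)N4CCN(c5ccccc5Br)CC4)cc3)[nH]c2c1=O`: 28%
Compound 3, `CCCn1c(=O)[nH]c2nc(-c3ccc(S(=O)(=O)N4CCN(c5cccc(Cl)c5)CC4)cc3)[nH]c2c1=O`: 21%

All three were tested in an assay on CHO cells for displacement of a labelled ligand from adenosine receptor A1 (Homo sapiens), read by scintillation counting, with a stated time of 90 min, tested at 1 uM, in the presence of a further agent that is not named here; a lower number here means less inhibition, a higher number more inhibition at the concentration tested (going by the name of the read-out). Compound 2 sits in the middle of the three numbers: the step of a number 3 percentage points lower from compound 1 to compound 2 (within the scatter) and the step of a number 7 percentage points lower from compound 2 to compound 3 (within the scatter) are both small, so the three compounds cannot be told apart on these data. The next compound, compound 4, `CCCn1c(=O)[nH]c2nc(-c3ccc(S(=O)(=O)N4CCN(C(C)c5ccccc5)CC4)cc3)[nH]c2c1=O`, differs from compound 2 by 1-phenylethyl in place of 2-bromophenyl on an amine nitrogen in a ring. Among the measured compounds shown here, the step most closely related is the one from compound 1 to compound 2, where a 4-bromobenzyl group on the same ring nitrogen was exchanged for an aryl group: a number 3 percentage points lower from compound 1 to compound 2 (within the scatter). Moving back from an aryl group to a benzyl-like group, as in 1-phenylethyl, is therefore not expected to shift the number beyond the scatter; the step of a number 2 percentage points higher from compound 2 to compound 4 (within the scatter) is expected to be small. Compound 4 is accordingly estimated at 30%, with a range from 18% to 42%.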

Compound 4, a percentage reported as inhibition, at one concentration (the size of the read-out at that concentration, not a potency): 42%
Beside the measured number, compound 4's estimate is 12 percentage points below it; the measured number falls inside the stated range.
By their numbers in this assay, from the lowest: compounds 3, 2 and 1 (each within the scatter of the next); then compound 4.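

In this assay, among the compounds shown here, this ring nitrogen shows, for the first time, a change beyond the scatter: 1-phenylethyl gives a number 14 percentage points higher from compound 2 to compound 4 (beyond the scatter), a number 21 percentage points higher from compound 3 to compound 4 (beyond the scatter) and a number 11 percentage points higher from compound 1 to compound 4 (beyond the scatter). The position therefore does respond to the group it carries, although the steps are modest. Compound 1 also has a carbon link between the ring nitrogen and its aromatic ring, so that link alone does not set compound 4 apart, and nothing available here explains the higher number.

On these data alone, the step from compound 1 to compound 4 combines an added methyl with a lost bromine, so their separate contributions remain open; a plain benzyl group on this nitrogen would help to separate them. As far as these compounds go, how a group with no aromatic ring, such as cyclohexyl, or one carrying a carboxylic acid would behave here also remains unknown.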